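A few compounds are considered here, and "the series" means these few. Any claim that something is new, unique, unknown or untested is made for them only; others in the source may bear on it.

- compound 1 `COc1ccc(SCc2ccc(/C=C/C(=O)Nc3ccccc3N)cc2)cc1OC` gives 21.9%
- compound 2 `Nc1ccccc1NC(=O)/C=C/c1ccc(CSc2ccc(Cl)cc2)cc1` gives 17.3%

In a functional assay on HeLa cells (Homo sapiens) for inhibition, read by CCK-8 assay, with a stated time of 72 h, tested at 8 uM (a lower number here means less inhibition of growth, a higher number more inhibition of growth at the concentration tested), compound 2 stands at 17.3%, the lower of two numbers that lie within the scatter of each other. Compound 3 `Nc1ccccc1NC(=O)/C=C/c1ccc(CSc2cccc(F)c2)cc1` carries 3-fluorophenyl in place of 4-chlorophenyl on a sulfur. Among the compounds with values here, the only measured step at this place is a number 4.6 percentage points lower from compound 1 to compound 2 (within the scatter), and it stays within the scatter. Within the data shown here, no measured step covers this exact exchange, so no change beyond the scatter is expected in this assay. The expected step is a number 1.7 percentage points higher from compound 2 to compound 3 (within the scatter). For compound 3 the estimate is 19%, with an expected range of 9% to 33%.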

Compound 3, percent growth inhibition at one concentration: 18.6%
For compound 3 the middle estimate is 0.4 percentage points above the measured one; low and high end bracket the measured number.
By their numbers in this assay, from the lowest: compounds 2, 3 and 1 (each within the scatter of the next).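

In this assay, 3-fluorophenyl in place of 4-chlorophenyl on a sulfur gives a number 1.3 percentage points higher from compound 2 to compound 3 (within the scatter), and 3-fluorophenyl in place of 3,4-dimethoxyphenyl gives a number 3.3 percentage points lower from compound 1 to compound 3 (within the scatter). All three phenyl groups on this sulfur therefore lie within the scatter of one another, so neither the exchange of chlorine for fluorine with its shift on the ring nor the loss of both methoxy groups separates these compounds. No supporting data bear on why these numbers lie so close. As far as these compounds go, whether an amine or a carboxylic acid on this phenyl ring would move the number beyond the scatter remains open.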